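Methylsulfanyl in place of benzylselanyl on two amidine cores

A few compounds are considered here, and "the series" means these few. Any claim that something is new, unique, unknown or untested is made for them only; others in the source may bear on it.

Measured so far:
Compound 1, `CS/C(=N\C(=O)c1ccno1)NC(=O)c1ccno1`: in a functional assay on MCF7 cells (Homo sapiens) for cytotoxicity, read by MTT assay, with a stated time of 72 h (on this read-out lower numbers stand for stronger inhibition of growth and higher numbers for weaker inhibition of growth), compound 1 reaches only a limit, > 100000 nM.
Compound 2, `O=C(/N=C(/NC(=O)c1ccno1)[Se]Cc1ccccc1)c1ccno1`: in this assay compound 2 also reaches only a limit, > 100000 nM.
Compound 3, `O=C(/N=C(/NC(=O)c1cc(-c2ccccc2)nc2ccccc12)[Se]Cc1ccccc1)c1cc(-c2ccccc2)nc2ccccc12`: in this assay compound 3 gives 45600 nM.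

Compounds 1 and 2 share one core, and compound 3 carries a different core; the difference between the two cores is not broken down here. Within the first core, compound 2 turns into compound 1 by the change (a group of 2 heavy atoms (1 carbon, 1 sulfur; no ring) in place of a group of 8 heavy atoms (7 carbon, 1 selenium; one six-membered aromatic ring of carbon only), on a carbon with a double bond to nitrogen). What this change did to growth inhibition is a step that the two limits leave unreadable from compound 2 to compound 1, and the size stays hidden because of the limit of > 100000 nM in this assay, at which 2 of the 3 values shown sit.

Compound 4, `CS/C(=N\C(=O)c1cc(-c2ccccc2)nc2ccccc12)NC(=O)c1cc(-c2ccccc2)nc2ccccc12`, is not yet measured. It arises from compound 3 by the same kind of change, (a group of 2 heavy atoms (1 carbon, 1 sulfur; no ring) in place of a group of 8 heavy atoms (7 carbon, 1 selenium; one six-membered aromatic ring of carbon only), on a carbon with a double bond to nitrogen), and the place is the same as in the first pair: a carbon with a double bond to nitrogen whose other neighbours are two amide-type nitrogens. For the measured compounds named here, compound 3 is the only compound here with a readable number, and the earlier pair gives no readable size for this change, so the expectation for compound 4 rests on compound 3 alone, whose value is 45600 nM. Compound 4 is expected to show roughly the step of a 1.8-fold higher number from compound 3 to compound 4 (0.24 log units; within the scatter) in this assay, with a real chance that only a limit is reported. The estimate for compound 4 is 80000 nM, within a range from 25000 nM to 250000 nM.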

Compound 4, concentration for total growth inhibition: 87700 nM
Beside the measured number, compound 4's estimate is 1.1-fold (0.04 log units) below it, within the range that was stated.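

In this assay, putting methylsulfanyl in place of benzylselanyl on the core of compound 3 gives a 1.9-fold higher number from compound 3 to compound 4 (0.28 log units; within the scatter), so the two compounds cannot be told apart on this read-out, and swapping the group on this core has no measurable effect on growth inhibition. The matching step from compound 2 to compound 1 cannot be read, because each of those two values is a limit and not a number: the limit of > 100000 nM in this assay, at which 2 of the 4 values shown sit.
For the compounds shown here, this leaves only one readable pair, so the data do not show whether the step carries over from one core to the other, and one pair on one cell line cannot establish a rule for the series.

The swap replaces the selenium atom and the aromatic ring in a single move, so the compounds shown leave open which of the two parts matters, if either does; benzylsulfanyl or methylselanyl on the same carbon would separate them. On these data alone, it also remains open how growth inhibition would respond to a quite different group at this place, such as an amine or a longer chain like hexylsulfanyl, on a core that gives readable numbers.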